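Hydroxy Added to a Core Where Both Parents Sit at the Limit

The source may hold more compounds than are shown below. What is called first, only, known or untested is meant among the compounds shown, and "the series" means these compounds.

Compound 1 `COc1cc(C2CCN(C[C@@H](C)O)CC2)ccc1Nc1ncc2ccc(-c3ccccc3N(C)S(C)(=O)=O)n2n1` and compound 2 `COc1cc(C2CCN(CC(N)=O)CC2)ccc1Nc1ncc2ccc(-c3ccccc3N(C)S(C)(=O)=O)n2n1` share one core and differ only in the chain attached to the ring amine nitrogen. In an in vitro ADME assay on microsomes from liver (Homo sapiens) for metabolic stability, using NADPH, with a stated time of 10 min, tested at 0.5 uM (a lower number here means that the compound disappears faster, a higher number that the compound lasts longer), compound 1 gives < 0.0834 h, which is a limit of the assay rather than a measured number. In this assay compound 2 likewise gives < 0.0834 h, again a limit. The step that the two limits leave unreadable from compound 1 to compound 2 therefore cannot be read, since both of its ends sit at the limit of < 0.0834 h in this assay, at which 2 of the 2 values shown sit. Compound 2 thus stands at the limit, with no numerical value of its own to compare against.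

Compound 3 `COc1cc(C2CCN(CC(N)=O)CC2)ccc1Nc1ncc2c(O)cc(-c3ccccc3N(C)S(C)(=O)=O)n2n1` has not yet been measured. It differs from compound 2 by hydroxy in place of hydrogen on an aromatic carbon. Going by the values given here, no measured step touches this part of the core, so the only guide is that every value seen so far sits at the limit of < 0.0834 h in this assay, at which 2 of the 2 values shown sit. Compound 3 is therefore expected to stay at or close to that limit, and the step that the limit leaves unreadable from compound 2 to compound 3 is estimated as one too small to read. For compound 3 the half-life in this assay is expected to be about 0.07 h, with a range from 0.03 h to 0.2 h.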

Compound 3, half-life: < 0.0834 h
Compound 3: a limit, no number; the forecaster's own chance of this, stated with the estimate: 70%; the middle value does not contradict the limit.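

Compound 2 and compound 3 both give a limit rather than a number in this assay, so the step between them, hydroxy in place of hydrogen on an aromatic carbon, cannot be read: the limit of < 0.0834 h in this assay, at which 3 of the 3 values shown sit.

The compounds shown leave open whether either change alters the half-life at all, and how long any compound sharing this core actually lasts.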